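Thiophene in Place of Chlorophenyl: An Expected Step

The source may report more compounds than this note shows. Statements on the series, on what has been measured and on what is new or still open speak of the compounds shown alone.

The three measured compounds share one core and differ only in the ring group that sits on it. Compound 1 `COc1cc(-c2cccc3nc(-c4cccc(Br)c4)oc23)cc(OC)c1OC` carries a 3-bromophenyl, and in a functional assay on NCI-H460 cells (Homo sapiens) for antiproliferative activity, read by MTT assay, with a stated time of 48 h (on this read-out lower numbers stand for stronger inhibition and higher numbers for weaker inhibition), compound 1 gives 3800 nM. Compound 2 `COc1cc(-c2cccc3nc(-c4ccc(Br)cc4)oc23)cc(OC)c1OC` carries a 4-bromophenyl. For compound 2 this assay reports only a limit, > 25000 nM. Compound 3 `COc1cc(-c2cccc3nc(-c4cccc(Cl)c4)oc23)cc(OC)c1OC` carries a 3-chlorophenyl. For compound 3 the read-out is likewise a limit, > 25000 nM, so no exact number is known for it. Two of the three values shown sit at this same limit (the limit of > 25000 nM in this assay, at which 2 of the 3 values shown sit), which places compound 3 at the unreadable end of the series.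

Compound 4 `COc1cc(-c2cccc3nc(-c4cccs4)oc23)cc(OC)c1OC` differs from compound 3 in one place: thiophen-2-yl in place of 3-chlorophenyl on an aromatic carbon.

Among the compounds with values here, two measured steps bear on changes of this pendant ring. Moving the bromo to the 4-position gave an at least 6.5-fold higher number from compound 1 to compound 2 (0.81 log units; beyond the scatter), and exchanging bromo for chloro gave an at least 6.5-fold higher number from compound 1 to compound 3 (0.81 log units; beyond the scatter). Both pushed the number to the limit. Between compound 2 and compound 3 the step is a step that the two limits leave unreadable from compound 2 to compound 3. No measured step involves a thiophen-2-yl, so the new change has no direct precedent among these compounds.

With compound 3 already at a limit, compound 4 is expected to give about 15000 nM, within 4000 nM to 25000 nM. That estimate means an expected step of an at least 1.6-fold lower number from compound 3 to compound 4 (0.22 log units; that floor lies within the scatter), which the limit may leave unreadable.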

Compound 4, half-maximal inhibitory concentration: 1600 nM
Compound 4: the middle estimate sits 9.4-fold (0.97 log units) above what was measured, outside the stated range (below it).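

In this assay, the group at this position does not need to be a halogen-bearing phenyl to give a readable number: thiophen-2-yl, a five-membered aromatic ring with no halogen on it, gives an at least 15-fold lower number from compound 3 to compound 4 (1.19 log units; beyond the scatter) and an at least 15-fold lower number from compound 2 to compound 4 (1.19 log units; beyond the scatter). Within the data shown here, it also improves on the only phenyl compound with an exact value, giving a 2.4-fold lower number from compound 1 to compound 4 (0.38 log units; beyond the scatter), so compound 4 has the lowest number of the four compounds, and the earlier steps, which only pushed the number to the limit, gave no sign of this. The values of compound 2 and compound 3 are limits and not numbers, so the two large steps are floors: the limit of > 25000 nM in this assay, at which 2 of the 4 values shown sit.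

This single change alters the ring size, puts sulfur into the ring and removes the halogen all at once, and the compounds shown cannot separate these three differences. From the compounds shown here alone, it remains open whether a plain unsubstituted phenyl, a furan-2-yl with oxygen in place of sulfur, or a thiophen-3-yl attached through its other ring carbon would give a number like that of compound 4.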